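Decyl Chain Replacing Hydroxyphenyl: An Expected Shift

A few compounds are considered here, and "the series" means these few. Any claim that something is new, unique, unknown or untested is made for them only; others in the source may bear on it.

Compound 1 `O=C1O/C(=C\Cn2cc(-c3ccc(Br)cc3)nn2)C(OCc2ccccc2)=C1OCc1ccccc1` in a functional assay on A549 cells (Homo sapiens) for antiproliferative activity, read by MTT assay, with a stated time of 72 h (on this read-out lower numbers stand for stronger inhibition and higher numbers for weaker inhibition), gives > 100000 nM, which is a limit of the assay rather than a number.
Compound 2 `O=C1O[C@H]([C@@H](O)Cn2cc(-c3cccc(O)c3)nn2)C(OCc2ccccc2)=C1OCc1ccccc1` in this assay gives 59900 nM.

For the measured compounds named here, of the two values shown, compound 2 holds the only actual number; the other value is a limit (the limit of > 100000 nM in this assay, at which 1 of the 2 values shown sits). Compound 3 `CCCCCCCCCCc1cn(C[C@H](O)[C@H]2OC(=O)C(OCc3ccccc3)=C2OCc2ccccc2)nn1` differs from compound 2 by decyl in place of 3-hydroxyphenyl on an aromatic carbon. Going by the values given here, no step between measured compounds is available, so the size of this change cannot be read from earlier pairs. Compound 3 is expected to come out near 20000 nM, within 5000 nM to 80000 nM. That estimate means a step from compound 2 to compound 3 of a 3.0-fold lower number from compound 2 to compound 3 (0.48 log units; beyond the scatter), expected as a modest gain in potency, with wide uncertainty.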

Compound 3, half-maximal inhibitory concentration: 6750 nM
Compound 3: the middle estimate sits 3.0-fold (0.47 log units) above what was measured; measured number inside the range.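

In this assay, for the compounds shown here, this position gives the first readable step: an 8.9-fold lower number from compound 2 to compound 3 (0.95 log units; beyond the scatter) for decyl in place of 3-hydroxyphenyl on an aromatic carbon. This place therefore accepts a chain with no ring and no hydrogen-bond donor, and the number falls rather than rises. Nothing shown here accounts for why the number moved. Open questions remain about how chain length matters, since a hexyl or dodecyl chain could behave differently. An amine at the end of the decyl chain is equally untested in what is shown.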